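This account rests on a few compounds, and the source may have more. Where it says the series, first, only, none or still open, it means among the compounds named here.

In a functional assay on T47D cells (Homo sapiens) for inhibition, read by CCK-8 assay, with a stated time of 72 h, tested at 10 uM (a lower number here means less inhibition of growth, a higher number more inhibition of growth at the concentration tested), compound 1 (`Cc1cccc(NC(=O)C2(C(=O)Nc3ccc(Nc4ncc5cc(C(=O)N(C)C)n(C6CCCC6)c5n4)cc3)CC2)c1`) stands at 95.3% and compound 2 (`CN(C)C(=O)c1cc2cnc(Nc3ccc(NC(=O)C4(C(=O)Nc5ccc(Cl)cc5)CC4)cc3)nc2n1C1CCCC1`) at 95% while compound 3 (`COc1ccc(NC(=O)C2(C(=O)Nc3ccc(Nc4ncc5cc(C(=O)N(C)C)n(C6CCCC6)c5n4)cc3)CC2)cc1`) stands at 96.1% so all three lie within the scatter of one another and compound 1 is not set apart from either. Compound 4 (`CN(C)C(=O)c1cc2cnc(Nc3ccc(NC(=O)C4(C(=O)Nc5ccc(Br)cc5)CC4)cc3)nc2n1C1CCCC1`) has not yet been measured. It differs from compound 1 by 4-bromophenyl in place of 3-methylphenyl on an amide-type nitrogen. Among the measured compounds shown here, two measured steps bear on this change: 4-chlorophenyl gives a number 0.3 percentage points lower from compound 1 to compound 2 (within the scatter) and 4-methoxyphenyl gives a number 0.8 percentage points higher from compound 1 to compound 3 (within the scatter) and on that ground no change beyond the scatter is expected in this assay for compound 4. The expected step is a number 0.2 percentage points higher from compound 1 to compound 4 (within the scatter) on this estimate. Compound 4 is estimated at 95.5% with a range from 91% to 99% for its growth inhibition.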

Compound 4, percent growth inhibition at one concentration: 94.3%
For compound 4 the middle estimate is 1.2 percentage points above the measured one; the range from low to high includes it.
By their numbers in this assay, from the lowest: compounds 4, 2, 1 and 3 (each within the scatter of the next).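

In this assay, 4-bromophenyl on the amide-type nitrogen gives a number 1 percentage points lower from compound 1 to compound 4 (within the scatter), while bromo in place of chloro gives a number 0.7 percentage points lower from compound 2 to compound 4 (within the scatter) and bromo in place of methoxy gives a number 1.8 percentage points lower from compound 3 to compound 4 (within the scatter). Bromo therefore joins chloro and methoxy among the aromatic-carbon groups here, and no step among these compounds passes beyond the scatter. Nothing measured here speaks to a cause for these steps. The compounds shown leave open whether an amine or a carboxylic acid on this phenyl ring, or a longer alkyl chain in place of the ring on the amide-type nitrogen, would move the number beyond the scatter.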